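The compounds below may be only part of what the source reports. "The series", "measured", "known", "first", "only" and "open" are said of these compounds alone.

In an ADME assay on WI-38 cells (Homo sapiens) for cytotoxicity, read by MTT assay, with a stated time of 48 h (a lower number here means a stronger inhibitor, a higher number a weaker inhibitor), compound 1 (`CC(C)(Oc1ccc(Cl)cc1)C(=O)NCCOC(=S)Nc1ccc(F)cc1`) gives > 800000 nM as a limit of the assay and not as a number. Among the measured compounds shown here, compound 2 (`CC(C)(Oc1ccc(Cl)cc1)C(=O)Oc1ccc(-c2cc(=S)ss2)cc1`) gives 764000 nM as the only numeric reading so far. For the measured compounds named here, no measured step links two closely related compounds, so the size of a single change cannot be read from the data. Compound 3 (`CC(C)(Oc1ccc(Cl)cc1)C(=O)NCCOC(=S)Nc1ccccc1`) derives from compound 1 with hydrogen in place of fluoro on an aromatic carbon, para to a large group, which takes 4-fluorophenyl to phenyl (hydrogen in place of fluoro on an aromatic carbon). The step expected in this assay lies within the usual scatter, with no direction favoured (a number no higher from compound 1 to compound 3 (the limit leaves the size open)). Compound 3 is estimated at 800000 nM with an expected range of 400000 nM to 1400000 nM in this assay. A limit rather than a number may be expected for compound 3.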

Compound 3, half-maximal inhibitory concentration: > 800000 nM
Compound 3: no number, only a limit; the forecaster's own chance of this, stated with the estimate: 65%; the middle value lies on the limit itself.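

Compound 1 and compound 3 each stand only as a limit in this assay, so no step between them can be read: the limit of > 800000 nM in this assay, at which 2 of the 3 values shown sit.

The compounds shown leave open whether going from 4-fluorophenyl to phenyl shifts the reading in this assay at all, and by how much.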